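Indane-to-dihydrobenzofuran exchange on the amide nitrogen

The source may report more compounds than this note shows. Statements on the series, on what has been measured and on what is new or still open speak of the compounds shown alone.

Within the data shown here, compound 3 `NC(=O)[C@@H](c1ccccc1)N(C(=O)c1ccccc1)[C@@H]1CCc2ncccc21` gives 19500 nM in an assay on HEK293T cells for antagonist activity at transient receptor potential cation channel subfamily M member 8 (Homo sapiens), read by fluorescence and calcium flux, with a stated time of 60 min (on this read-out lower numbers stand for stronger inhibition and higher numbers for weaker inhibition), the highest of the three numbers so far: compound 1 `C[C@H](c1ccccc1)N(C(=O)c1ccccc1)[C@@H](C(N)=O)c1ccccc1` gives 1200 nM and compound 2 `NC(=O)[C@@H](c1ccccc1)N(C(=O)c1ccccc1)[C@@H]1CCc2ccccc21` gives 270 nM. Compound 4 `NC(=O)[C@@H](c1ccccc1)N(C(=O)c1ccccc1)[C@@H]1COc2ccccc21` differs from compound 3 by a group of 9 heavy atoms (8 carbon, 1 oxygen; one five-membered non-aromatic ring with 1 hetero atom, one six-membered aromatic ring of carbon only) in place of a group of 9 heavy atoms (8 carbon, 1 nitrogen; one five-membered non-aromatic ring of carbon only, one six-membered aromatic ring with 1 hetero atom), on an amide-type nitrogen. Among the measured compounds shown here, two measured steps bear on this: a 72-fold higher number from compound 2 to compound 3 (1.86 log units; beyond the scatter), in which a hetero atom entered the aromatic ring, and a 4.4-fold lower number from compound 1 to compound 2 (0.65 log units; beyond the scatter). For the measured compounds named here, compound 4 restores the carbon-only aromatic ring of compound 2 but carries an oxygen in the five-membered ring, a change with no measured precedent in this set. A large step down in this assay is therefore expected, though with uncertainty about a full return to the level of compound 2. Compound 4 is expected at 600 nM (range 150 nM to 3000 nM), meaning a 33-fold lower number from compound 3 to compound 4 (1.51 log units; beyond the scatter).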

Compound 4, half-maximal inhibitory concentration: 3300 nM
Compound 4: the middle estimate sits 5.5-fold (0.74 log units) below what was measured; measured number outside the range, above it.
By their numbers in this assay, from the lowest: compound 2; then compound 1; then compound 4; then compound 3.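

In this assay, moving the hetero atom out of the aromatic ring and into the five-membered ring as oxygen recovers only part of the number: a 5.9-fold lower number from compound 3 to compound 4 (0.77 log units; beyond the scatter), yet still a 12-fold higher number from compound 2 to compound 4 (1.09 log units; beyond the scatter). Compound 4 also falls short of the 1-phenylethyl group, with a 2.8-fold higher number from compound 1 to compound 4 (0.44 log units; beyond the scatter). Among the bicyclic groups on this amide-type nitrogen, a hetero atom in either ring goes with a higher number than the carbon-only group of compound 2. Nothing available explains these differences. Open, as far as these compounds go, is whether a fluoro or methoxy substituent on the 2,3-dihydro-1H-inden-1-yl group would keep the level of compound 2.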